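Adding an ethyl group at the carbon bearing the sulfur

A few compounds are considered here, and "the series" means these few. Any claim that something is new, unique, unknown or untested is made for them only; others in the source may bear on it.

Measured compounds:
compound 1 `COc1ccc(C(CCCCCN2CCc3cc(OC)c(OC)cc3C2)Sc2ccc(C)cc2)cc1OC` — 330 nM
compound 2 `COc1ccc(C(CCCCCN2CCc3cc(OC)c(OC)cc3C2)SC(C)(C)C)cc1OC` — 3580 nM

For the measured compounds named here, in a functional assay on S1B1-20 cells (Homo sapiens) (a higher number here means a weaker inhibitor, a lower number a stronger inhibitor), compound 1 gives 330 nM, the lowest of the two numbers; the only neighbour, compound 2, gives 3580 nM, which is an 11-fold higher number from compound 1 to compound 2 (1.04 log units; beyond the scatter). Compound 3 `CCC(CCCCCN1CCc2cc(OC)c(OC)cc2C1)(Sc1ccc(C)cc1)c1ccc(OC)c(OC)c1` differs from compound 1 by ethyl in place of hydrogen on a saturated chain carbon bound to an aromatic carbon, a saturated chain carbon and a sulfur. Going by the values given here, the one measured step, from compound 1 to compound 2, concerns the group on the sulfur, not this carbon, so it does not bear on the change. With no guidance, the step for compound 3 is expected to be a 1.8-fold higher number from compound 1 to compound 3 (0.26 log units; within the scatter), a modest weakening at most. Compound 3 is therefore estimated at 600 nM in this assay, between 150 nM and 2500 nM.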

Compound 3, half-maximal inhibitory concentration: 1230 nM
Compound 3: the middle estimate sits 2.1-fold (0.31 log units) below what was measured; low and high end bracket the measured number.
By their numbers in this assay, from the lowest: compound 1; then compound 3; then compound 2.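

In this assay, ethyl in place of hydrogen on the saturated chain carbon bound to an aromatic carbon, a saturated chain carbon and a sulfur gives a 3.7-fold higher number from compound 1 to compound 3 (0.57 log units; beyond the scatter) and so shows that this carbon, unchanged in the earlier pair, also affects the number. The 4-methylphenyl on the sulfur stays in place, so the step belongs to this one change. Nothing available explains the step. As far as these compounds go, whether methyl, a longer chain or a hydroxyl group at this carbon would give a smaller or larger step remains open. So does whether the ethyl step would hold with tert-butyl on the sulfur.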